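The compounds below may be only part of what the source reports. "The series", "measured", "known", "first", "only" and "open" are said of these compounds alone.

Measured compounds:
compound 1, `CC(C)(C)N(NC(=O)c1ccccc1Cl)C(=O)c1ccccc1Cl`, 331 nM
compound 2, `CC(C)(C)N(NC(=O)c1cccc(C#N)c1)C(=O)c1ccccc1Cl`, 955 nM

Both were run in an assay on cells for agonist activity at ecdysone receptor (Bombyx mori), read by a luciferase reporter, with a stated time of 24 h; on this read-out lower numbers stand for an effect already at smaller amounts and higher numbers for an effect only at larger amounts of compound. Compound 2 carries the highest of the two numbers; the nearest is compound 1, reached by a 2.9-fold higher number from compound 1 to compound 2 (0.46 log units; beyond the scatter), a modest step that swaps the group on one carbonyl carbon. Compound 3, `Cc1cccc(C(=O)NN(C(=O)c2ccccc2Cl)C(C)(C)C)c1`, keeps the 3-substituted ring of compound 2 and differs only by methyl in place of cyano on an aromatic carbon. Among the measured compounds shown here, no measured step covers this exact change; the only step in hand concerns a different swap at the same carbonyl, and it says nothing about cyano against methyl on that ring. The expectation therefore rests on little: the step from compound 2 to compound 3 is estimated as a 1.4-fold lower number from compound 2 to compound 3 (0.13 log units; within the scatter), small and possibly within the scatter, with a slightly lower number considered somewhat more likely than a higher one. Compound 3 is expected at about 700 nM, within a range of 250 nM to 2000 nM.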

Compound 3, half-maximal effective concentration: 603 nM
For compound 3 the middle estimate is 1.2-fold (0.06 log units) above the measured one; measured number inside the range.
By their numbers in this assay, from the lowest: compounds 1, 3 and 2 (each within the scatter of the next, the first and the last beyond it).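

In this assay the change at this place on the ring, meta to a large group, gives a 1.6-fold lower number from compound 2 to compound 3 (0.20 log units; within the scatter) so methyl and cyano cannot be told apart here with the rest of the core held. The comparison with the 2-chlorophenyl group gives a 1.8-fold higher number from compound 1 to compound 3 (0.26 log units; within the scatter) so the separation seen in a 2.9-fold higher number from compound 1 to compound 2 (0.46 log units; beyond the scatter) does not extend to 3-methylphenyl, and a 3-substituted ring is not set apart from compound 1 as such. No measurement at hand bears on why the numbers fall this way.

Open, going by these compounds, is whether an amine, a carboxylic acid or a longer chain at the same place on the ring would stay within this narrow spread. Also open, on these data alone, is whether methyl and cyano would still read alike with a different group on the other carbonyl.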